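The source may hold more compounds than are shown below. What is called first, only, known or untested is meant among the compounds shown, and "the series" means these compounds.

Series notes. Compound 1 `CC(C)(C)c1cc(CC2SC(=O)N=C2O)cc(C(C)(C)C)c1O` carries no result in an assay on isolated protein for inhibition of Amine oxidase [flavin-containing] A (Homo sapiens), read by fluorescence; on this read-out lower numbers stand for stronger inhibition and higher numbers for weaker inhibition: for compound 1 the entry reads "not determined" (no result reported). Going by the values given here, compound 2 `Cc1cc(C)cc(CC2SC(=O)NC2=O)c1` is the only compound with a number; in this assay compound 2 gives 50500 nM, so it stands alone, with nothing measured to set beside it. Compound 3 `Cc1cc(CC2SC(=O)NC2=O)cc(C)c1O` is not yet measured and differs from compound 2 by one change: hydroxy in place of hydrogen on an aromatic carbon. Among the compounds with values here, no step between measured compounds exists, so the effect of this change is untested in this assay. The expected step, a 1.4-fold lower number from compound 2 to compound 3 (0.16 log units; within the scatter), is small, not clearly beyond the scatter in either direction. For compound 3 the estimate in this assay is 35000 nM, with a range from 12000 nM to 100000 nM.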

Compound 3, half-maximal inhibitory concentration: 26200 nM
Compound 3: the middle estimate sits 1.3-fold (0.13 log units) above what was measured; the measured number falls inside the stated range.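

Working from the first measured pair in this assay, hydroxy in place of hydrogen, on the aromatic carbon ortho to two methyl groups, gives a 1.9-fold lower number from compound 2 to compound 3 (0.28 log units; within the scatter) and so leaves the number indistinguishable from that of the parent. Going by these compounds alone, at this position, the added hydroxy therefore brings no step that can be told from the scatter. Nothing at hand bears on the reason for this result. On these data alone, whether a methoxy or an amine on this carbon would give a step beyond the scatter remains open. So does whether the hydroxy step would hold with ethyl groups in place of the two methyl groups.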